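Series notes: phenyl for cyclohexyl next to the ring oxygen

The source may report more compounds than this note shows. Statements on the series, on what has been measured and on what is new or still open speak of the compounds shown alone.

Three compounds of the shared core have numbers in a functional assay on DU-145 cells (Homo sapiens) for cytotoxicity, read by MTT assay, with a stated time of 72 h; on this read-out higher numbers stand for an effect only at larger amounts of compound and lower numbers for an effect already at smaller amounts. Compound 1 `O=c1cc(NC2CCCCC2)cc(/C=C/c2ccccc2)o1` gives 1.23 uM. Compound 3 `O=c1cc(Nc2ccccc2)cc(-c2ccccc2)o1` gives 0.098 uM. Compound 2 `COc1ccc(Nc2cc(C3CCCCC3)oc(=O)c2)cc1` gives 8.61 uM, the highest of the three numbers; its gap to compound 1 and its larger gap to compound 3 both lie beyond the scatter. Each pair of these compounds differs at more than one place, so no single step between measured compounds can be drawn, and the values are only set side by side.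

Compound 4 `COc1ccc(Nc2cc(-c3ccccc3)oc(=O)c2)cc1` is not yet measured. It differs from compound 2 in one place: phenyl in place of cyclohexyl on an aromatic carbon. Compound 3 also carries a phenyl next to the ring oxygen, while compound 2 carries the cyclohexyl there, but compound 3 and compound 2 differ elsewhere as well, so the change cannot be read off a measured pair. Since compound 3 gives 0.098 uM and compound 2 gives 8.61 uM, a move toward lower numbers in this assay is expected for the phenyl. The step expected in this assay is a 17-fold lower number from compound 2 to compound 4 (1.24 log units; beyond the scatter), beyond the scatter. Compound 4 is estimated at 0.5 uM, with a range from 0.1 uM to 3 uM.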

Compound 4, concentration for half-maximal effect: 0.12 uM
Beside the measured number, compound 4's estimate is 4.2-fold (0.62 log units) above it; measured number inside the range.
By their numbers in this assay, from the lowest: compounds 3 and 4 (each within the scatter of the next); then compound 1; then compound 2.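

In this assay, among these compounds, the first single-place reading at the position next to the ring oxygen is phenyl in place of cyclohexyl, which gives a 72-fold lower number from compound 2 to compound 4 (1.86 log units; beyond the scatter) and so accounts for a large step on its own. The two groups have the same count of heavy atoms, donors and acceptors and differ in that one ring is aromatic and the other is non-aromatic, so in this pair the aromatic ring goes with the lower number. The second step, methoxy in place of hydrogen on an aromatic carbon, reads a 1.2-fold higher number from compound 3 to compound 4 (0.09 log units; within the scatter) and leaves the number unchanged within the scatter when phenyl occupies this position, while no measurement at hand explains either step.

The compounds shown leave open whether a methyl, a pyridyl or a longer chain at this position would give numbers like that of compound 4 or like that of compound 2. They also leave open whether the phenyl step carries over to compounds with a cyclohexyl on the amino nitrogen, as in compound 1, or to the same change in other cell lines.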